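This account rests on a few compounds, and the source may have more. Where it says the series, first, only, none or still open, it means among the compounds named here.

Measured so far in a functional assay on A549 cells (Homo sapiens) for antiproliferative activity, read by MTT assay, with a stated time of 72 h; a lower number here means a stronger inhibitor, a higher number a weaker inhibitor:
- compound 1 `O=C(Nc1ccc(Cl)c(-c2nnc3c(Cl)cccn23)c1)c1ccc(Cl)cc1Cl`: 61300 nM
- compound 2 `O=C(Nc1ccc(Cl)c(-c2nnc3c(Cl)cccn23)c1)c1cccnc1Cl`: 35800 nM

Within the data shown here, compound 2 gives the lower of the two numbers, but its only neighbour is compound 1, and the step of a 1.7-fold lower number from compound 1 to compound 2 (0.23 log units; within the scatter) lies within the scatter, so no ordering between the two can be claimed.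

Compound 3 `O=C(Nc1ccc(Cl)c(-c2nnc3c(Cl)cccn23)c1)c1ccccc1Cl` is the next member. Its change from compound 2 is 2-chlorophenyl in place of 2-chloropyridin-3-yl on a carbonyl carbon. Among the measured compounds shown here, the one measured step that bears on it is the exchange of the aryl group on the same carbonyl carbon, a 1.7-fold lower number from compound 1 to compound 2 (0.23 log units; within the scatter), which did not move the number beyond the scatter; compound 3 also carries a group that differs from the 2,4-dichlorophenyl of compound 1 only by one chlorine. Nothing here points to a step beyond the scatter in this assay in either direction. For compound 3 the expected value is 45000 nM, with a range of 20000 nM to 100000 nM. The step this estimate implies, a 1.3-fold higher number from compound 2 to compound 3 (0.10 log units; within the scatter), is expected to stay within the scatter.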

Compound 3, half-maximal inhibitory concentration: > 100000 nM
Compound 3: only a limit was reported (the forecaster's own chance of this, stated with the estimate: 10%); middle value at least 2.2-fold (0.34 log units) away from the limit.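

In this assay, among these compounds, the exchange on a carbonyl carbon of 2-chloropyridin-3-yl for 2-chlorophenyl gives an at least 2.7-fold higher number from compound 2 to compound 3 (0.44 log units; beyond the scatter), the only step so far that is printed as beyond the scatter, so the aryl group at this place can affect the number after all. As far as these compounds go, compound 3 is reported only as a limit, so the full size of that step stays unknown: the limit of > 100000 nM in this assay, at which 1 of the 3 values shown sits. Hydrogen in place of chloro on an aromatic carbon gives an at least 1.6-fold higher number from compound 1 to compound 3 (0.21 log units; that floor lies within the scatter), and with that floor inside the scatter, no ordering of these two compounds can be claimed.

Still open is whether the ring nitrogen alone accounts for the step in other settings, since only one such pair is shown. Also open, from the compounds shown here alone, is how an amine or a carboxylic acid on this aryl group would read in the same assay.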